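The source may report more compounds than this note shows. Statements on the series, on what has been measured and on what is new or still open speak of the compounds shown alone.

Compound 1 `Cn1ncc(-c2nn(C)c3ncnc(N4CCC4)c23)c1-c1ccccc1` is one of three compounds examined in an ADME assay on microsomes from liver (Homo sapiens) for metabolic stability; on this read-out higher numbers stand for fast clearance and lower numbers for slow clearance. In this assay compound 1 gives 34 mL/min/kg. Compound 2 `CC(C)Cc1nn(C)c2ncnc(N3Cc4ccccc4C3)c12` gives 123 mL/min/kg in this assay, a higher number than compound 1 by a margin that lies beyond the usual scatter of the measurement. Compound 3 `CCCOc1cncc2nnc(-c3cnn(C)c3-c3ccc(C(F)(F)F)cc3)n12` is reported in this assay only as a limit of the method, > 300 mL/min/kg, and not as a number; this corresponds to the limit of > 300 mL/min/kg in this assay, at which 1 of the 3 values shown sits. Among the numbers actually given, compound 1 therefore stands at the low end.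

Compound 4 `Cn1ncc(-c2nn(C)c3ncnc(N4CCC4)c23)c1-c1ncc(C2CC2)cn1` has not yet been measured in this assay. It differs from compound 1 in one place: 5-cyclopropylpyrimidin-2-yl in place of phenyl on an aromatic carbon. The group that leaves is a plain phenyl; the group that enters is 5-cyclopropylpyrimidin-2-yl, carrying two hydrogen-bond acceptors where phenyl carried none, on the same aromatic carbon of the five-membered ring with two nitrogen atoms.

For the measured compounds named here, no measured pair in this set shares this change, so there is no observed step to lean on. The step from compound 1 to compound 4 is expected to be small, within or only slightly beyond the scatter, and if anything toward a lower number: a 1.2-fold lower number from compound 1 to compound 4 (0.08 log units; within the scatter). Compound 4 is accordingly estimated to give about 28 mL/min/kg in this assay, within a range from 12 mL/min/kg to 65 mL/min/kg.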

Compound 4, clearance: 28 mL/min/kg
Compound 4: the middle estimate sits on the measured number at the digits printed; the range from low to high includes it.
By their numbers in this assay, from the lowest: compounds 4 and 1 (each within the scatter of the next); then compound 2. At a limit, above all of these: compound 3.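

In this assay, putting 5-cyclopropylpyrimidin-2-yl in place of phenyl gives a 1.2-fold lower number from compound 1 to compound 4 (0.08 log units; within the scatter), the only step shown at this place, an aromatic carbon of a five-membered aromatic ring with 2 nitrogen. The read-out therefore stays within the scatter even though the entering group is larger, adds a three-membered non-aromatic ring of carbon only and brings hydrogen-bond acceptors that phenyl lacked. Nothing measured in this set bears on why the two compounds lie so close.

The single step joins two changes in one group, the ring nitrogen atoms and the cyclopropyl, so the compounds shown leave open what each contributes alone, and a plain pyrimidin-2-yl or a pyridin-2-yl at this place would be needed to separate them. Also open, on these data alone, is whether the read-out would stay as close with a different group at the 5-position of the pyrimidine, such as a primary amine or a carboxylic acid in place of the cyclopropyl, and whether the same exchange behaves alike on a different core.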